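The source may hold more compounds than are shown below. What is called first, only, known or untested is meant among the compounds shown, and "the series" means these compounds.

In an assay on isolated protein for inhibition of alpha-ketoglutarate-dependent dioxygenase alkB homolog 3 (Homo sapiens), read by polymerase chain reaction, with a stated time of 1 h (a lower number here means a stronger inhibitor, a higher number a weaker inhibitor), compound 3 `Cc1ccc2[nH]c(-n3[nH]c(C)c(Cc4ccc(Cl)cc4)c3=O)nc2c1` gives 750 nM. Among the three measured compounds it stands second highest: compound 1 `Cc1ccc2[nH]c(-n3[nH]c(C)c(Cc4ccc(C(F)(F)F)cc4)c3=O)nc2c1` gives 570 nM, with a 1.3-fold higher number from compound 1 to compound 3 (0.12 log units; within the scatter), while compound 2 `Cc1ccc2[nH]c(-n3[nH]c(C)c(Cc4ccc(-c5ccccc5)cc4)c3=O)nc2c1` gives 5300 nM, with a 7.1-fold lower number from compound 2 to compound 3 (0.85 log units; beyond the scatter). Compound 4 `Cc1ccc2[nH]c(-n3[nH]c(C)c(Cc4ccc(C(C)(C)C)cc4)c3=O)nc2c1` differs from compound 3 by tert-butyl in place of chloro on an aromatic carbon. The measured steps that bear on this are the two steps involving the largest substituent: a 9.3-fold higher number from compound 1 to compound 2 (0.97 log units; beyond the scatter) and a 7.1-fold lower number from compound 2 to compound 3 (0.85 log units; beyond the scatter), both weakening with the bulkier group, whereas a 1.3-fold higher number from compound 1 to compound 3 (0.12 log units; within the scatter) shows the two small groups near each other. Since tert-butyl is larger than chloro but carries no ring, compound 4 is expected to be somewhat weaker than compound 3, with an expected step of a 2.4-fold higher number from compound 3 to compound 4 (0.38 log units; beyond the scatter) in this assay. The estimate for compound 4 is 1800 nM, within a range of 600 nM to 5000 nM.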

Compound 4, half-maximal inhibitory concentration: 3700 nM
The estimate for compound 4 lay 2.1-fold (0.31 log units) below the measured number, and the stated range covers the measured number.
By their numbers in this assay, from the lowest: compounds 1 and 3 (each within the scatter of the next); then compounds 4 and 2 (each within the scatter of the next).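

In this assay, the higher number at this position, para to a large group, does not depend on a ring: tert-butyl gives a 4.9-fold higher number from compound 3 to compound 4 (0.69 log units; beyond the scatter), and against trifluoromethyl it gives a 6.5-fold higher number from compound 1 to compound 4 (0.81 log units; beyond the scatter). Tert-butyl and phenyl read alike, with a 1.4-fold lower number from compound 2 to compound 4 (0.16 log units; within the scatter), so phenyl is no longer the only group with a number this high. Nothing measured here explains this change. The compounds shown leave open whether an isopropyl group would read with chloro or with tert-butyl. They also leave open how an amine or a carboxylic acid would read at this position.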